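A few compounds are considered here, and "the series" means these few. Any claim that something is new, unique, unknown or untested is made for them only; others in the source may bear on it.

Measured so far in a functional assay on HEL cells (Homo sapiens) for cytotoxicity, read by microscopy; a lower number here means that less compound is tolerated, a higher number that more compound is tolerated:
- compound 1, `Cc1cn([C@@H]2O[C@H](CO[Si](C)(C)C(C)(C)C)[C@@]3(OS(=O)(=O)C=C3NCCC(N)=O)[C@H]2O[Si](C)(C)C(C)(C)C)c(=O)n(C)c1=O`: >= 80000 nM
- compound 2, `Cc1cn([C@@H]2O[C@H](CO[Si](C)(C)C(C)(C)C)[C@@]3(OS(=O)(=O)C=C3NCCC(=O)O)[C@H]2O[Si](C)(C)C(C)(C)C)c(=O)n(C)c1=O`: 80000 nM
- compound 3, `Cc1cn([C@@H]2O[C@H](CO[Si](C)(C)C(C)(C)C)[C@@]3(OS(=O)(=O)C=C3NCC(=O)C(=O)N3CCC3)[C@H]2O[Si](C)(C)C(C)(C)C)c(=O)n(C)c1=O`: 65000 nM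

The value of compound 1 in this assay is a limit, not a number. Of the two numbers, compound 3 and compound 2 sit within the scatter of each other, the step being a 1.2-fold lower number from compound 2 to compound 3 (0.09 log units; within the scatter); compound 3 thus stands nowhere apart from compound 2 on the numbers shown. The step from the limit of compound 1 is an at least 1.2-fold lower number from compound 1 to compound 3 (0.09 log units; that floor lies within the scatter), its floor also within the scatter.

Compound 4 is `Cc1cn([C@@H]2O[C@H](CO[Si](C)(C)C(C)(C)C)[C@@]3(OS(=O)(=O)C=C3NCC(N)=O)[C@H]2O[Si](C)(C)C(C)(C)C)c(=O)n(C)c1=O`. It differs from compound 3 in that (amino in place of (azetidin-1-yl)carbonyl on a carbonyl carbon). Going by the values given here, the steps that bear on this change are those at the same chain carbon bound to the amine nitrogen, both small: an at least 1.2-fold lower number from compound 1 to compound 3 (0.09 log units; that floor lies within the scatter) and a 1.2-fold lower number from compound 2 to compound 3 (0.09 log units; within the scatter). Neither reaches beyond the scatter, so no step beyond the scatter is expected from compound 3 to compound 4 in this assay, and the closest comparator by structure, compound 1, sits at a limit, which leaves room for compound 4 to reach the limit as well.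

Compound 4 is expected to give about 75000 nM in this assay, within 50000 nM to 110000 nM. The expected step is a 1.2-fold higher number from compound 3 to compound 4 (0.06 log units; within the scatter).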

Compound 4, minimum cytotoxic concentration: 16000 nM
Compound 4: middle estimate off by 4.7-fold (0.67 log units), on the high side; measured number outside the range, below it.
By their numbers in this assay, from the lowest: compound 4; then compounds 3 and 2 (each within the scatter of the next).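

In this assay, going by these compounds alone, no step that could be read at the saturated chain carbon bound to the amine nitrogen had left the scatter until compound 4, so this position had looked indifferent to the group it carries. Carbamoyl at that carbon changes this, with amino in place of (azetidin-1-yl)carbonyl on the carbonyl carbon giving a 4.1-fold lower number from compound 3 to compound 4 (0.61 log units; beyond the scatter), and carbamoyl in place of carboxymethyl giving a 5.0-fold lower number from compound 2 to compound 4 (0.70 log units; beyond the scatter), while carbamoyl in place of carbamoylmethyl gives an at least 5.0-fold lower number from compound 1 to compound 4 (0.69 log units; beyond the scatter). That last step has only a floor, since compound 1 stands at a limit and not at a number: the limit of >= 80000 nM in this assay, at which 1 of the 4 values shown sits.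

The compounds shown leave open whether the lower number belongs to the carbamoyl group itself or to its sitting directly on that chain carbon rather than as carbamoylmethyl. A carboxylic acid on the same carbon, set against compound 4 and compound 2, would begin to separate these two readings, and a methyl amide or an azetidine amide in the same place would show whether the free amide hydrogens matter.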